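Bulky Cyclohexyl Replaces Fluorine on the Aryl Thiosemicarbazone

This account rests on a few compounds, and the source may have more. Where it says the series, first, only, none or still open, it means among the compounds named here.

Measured so far:
compound 1 `O=C1Nc2ccccc2/C1=N/NC(=S)Nc1cccnc1`: > 50000 nM
compound 2 `CC(C)NC(=S)N/N=C1\C(=O)Nc2ccccc21`: 10300 nM
compound 3 `O=C1Nc2ccccc2/C1=N/NC(=S)Nc1ccc(F)cc1`: 1920 nM

Three compounds on the shared core differ only in the group on the amide-type nitrogen. In a functional assay on KB-V1 cells (Homo sapiens) for cytotoxicity, read by MTT assay, with a stated time of 72 h (on this read-out higher numbers stand for weaker inhibition and lower numbers for stronger inhibition), compound 1 reaches only the limit of the assay, > 50000 nM, noted as the limit of > 50000 nM in this assay, at which 1 of the 3 values shown sits. Compound 2, with isopropyl in place of pyridin-3-yl, gives 10300 nM, a change of an at least 4.8-fold lower number from compound 1 to compound 2 (0.68 log units; beyond the scatter). Compound 3, with 4-fluorophenyl, gives 1920 nM, the lowest number among the two measured values; the step of a 5.4-fold lower number from compound 2 to compound 3 (0.73 log units; beyond the scatter) and the step of an at least 26-fold lower number from compound 1 to compound 3 (1.41 log units; beyond the scatter) both lie beyond the scatter.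

Compound 4 `CCCC1CCC(c2ccc(NC(=S)N/N=C3\C(=O)Nc4ccccc43)cc2)CC1` is not yet measured. It differs from compound 3 by 4-propylcyclohexyl in place of fluoro on an aromatic carbon. For the measured compounds named here, no measured step changes a group on the aromatic carbon, so the steps on the nitrogen bear on it only by showing that the aryl-bearing compound 3 gave the lowest number. A modest step in either direction, or none beyond the scatter, is possible; the expectation is a somewhat lower number, a 2.7-fold lower number from compound 3 to compound 4 (0.44 log units; beyond the scatter). Compound 4 is therefore estimated at 700 nM, between 150 nM and 3500 nM.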

Compound 4, half-maximal inhibitory concentration: 11000 nM
Compound 4: middle estimate off by 16-fold (1.20 log units), on the low side; the measured number lies above the stated range.
By their numbers in this assay, from the lowest: compound 3; then compounds 2 and 4 (each within the scatter of the next). At a limit, above all of these: compound 1.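

For the compounds shown here, this is the first measured change on an aromatic carbon of the ring that compound 3 carries on its nitrogen: 4-propylcyclohexyl in place of fluoro gives a 5.7-fold higher number from compound 3 to compound 4 (0.76 log units; beyond the scatter) in this assay. An aromatic ring on the nitrogen therefore does not by itself secure the low number of compound 3, as compound 4 keeps that ring and still moves to a higher number, so the group on the aromatic carbon matters as well. Nothing measured here gives a reason for this step.

The compounds shown leave open whether methyl, chloro or an amine on the same aromatic carbon would stay close to fluoro or move toward 4-propylcyclohexyl. They also leave open whether an unsubstituted cyclohexyl ring, without the propyl chain, would give a similar number.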